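The source may report more compounds than this note shows. Statements on the series, on what has been measured and on what is new or still open speak of the compounds shown alone.

Compound 1 `O=S(=O)(NC1=NCCN1C(=S)SN1CCn2c1nsc2=S)c1ccccc1` joins a plain phenyl to the sulfonyl sulfur of the shared core. In a functional assay on KYSE-510 cells (Homo sapiens) for antiproliferative activity, read by crystal violet staining, with a stated time of 96 h (a higher number here means a weaker inhibitor of growth, a lower number a stronger inhibitor of growth), compound 1 gives >= 20000 nM, which is a limit of the assay rather than a number. Compound 2 `O=S(=O)(NC1=NCCN1C(=S)SN1CCn2c1nsc2=S)c1ccc(C(F)(F)F)cc1` adds a trifluoromethyl to that phenyl, and in this assay compound 2 also gives >= 20000 nM, again a limit. Compound 3 `COc1ccc(S(=O)(=O)NC2=NCCN2C(=S)SN2CCn3c2nsc3=S)cc1OC` puts a 3,4-dimethoxyphenyl on the sulfonyl sulfur, and in this assay compound 3 gives >= 20000 nM, once more a limit. The steps a step that the two limits leave unreadable from compound 1 to compound 2, a step that the two limits leave unreadable from compound 1 to compound 3 and a step that the two limits leave unreadable from compound 2 to compound 3 therefore cannot be read, because every value sits at the limit of >= 20000 nM in this assay, at which 3 of the 3 values shown sit. Compound 1 thus stands nowhere better than its two companions; all three rest at the same limit.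

Compound 4 `O=S(=O)(NC1=NCCN1C(=S)SN1CCn2c1nsc2=S)c1cccc(OC(F)(F)F)c1` is compound 1 changed by trifluoromethoxy in place of hydrogen on an aromatic carbon. Going by the values given here, no measured step bears a readable size on this change: the three aryl variations so far all ended at the limit, so there is no gradient to follow. Compound 4 is accordingly expected to show no step beyond the scatter in this assay, the estimated step of a number no higher from compound 1 to compound 4 (the limit leaves the size open) being essentially flat. Compound 4 is estimated at 20000 nM, with a range from 10000 nM to 40000 nM, and most probably it too will be reported only as a limit.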

Compound 4, concentration for 50% growth inhibition: >= 20000 nM
Compound 4: no number, only a limit (the forecaster's own chance of this, stated with the estimate: 80%); the middle value lies on the limit itself.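

Compound 4, like compound 1, gives only a limit and not a number in this assay, so the step between these two compounds cannot be read, and all four compounds rest at the same point: the limit of >= 20000 nM in this assay, at which 4 of the 4 values shown sit.

The compounds shown leave open whether these aryl groups on the sulfonyl sulfur differ at all in their inhibition of growth.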